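This account rests on a few compounds, and the source may have more. Where it says the series, first, only, none or still open, it means among the compounds named here.

Of the compounds shown here, two have so far been measured in an assay on isolated protein for displacement of a labelled ligand from acyl-CoA:cholesterol acyltransferase (Oryctolagus cuniculus); on this read-out higher numbers stand for weaker inhibition and lower numbers for stronger inhibition. Compound 1 `CC(C)c1cccc(C(C)C)c1NC(=O)Nc1nc2ccccc2n1-c1ccc(Cl)cc1` gives 280 nM, and compound 2 `Cc1ccccc1-n1c(NC(=O)Nc2c(C(C)C)cccc2C(C)C)nc2ccccc21` gives 19 nM. Going by the values given here, on these numbers compound 2 stands lowest of the two, the only other value being that of compound 1, and the single measured step, a 15-fold lower number from compound 1 to compound 2 (1.17 log units; beyond the scatter), separates them. Compound 3 `CC(C)c1cccc(C(C)C)c1NC(=O)Nc1nc2ccccc2n1-c1ccccc1C(F)(F)F` belongs to the same series and has not yet been measured. It differs from compound 2 in one place: trifluoromethyl in place of methyl on an aromatic carbon. Among the compounds with values here, no measured step concerns this change; the one step recorded, a 15-fold lower number from compound 1 to compound 2 (1.17 log units; beyond the scatter), exchanges 4-chlorophenyl for 2-methylphenyl on the aromatic nitrogen and says nothing about exchanging methyl for trifluoromethyl on an aromatic carbon. Within the data shown here, with no step bearing on it, the expectation for compound 3 in this assay is a number close to that of compound 2, and the expected step is a 1.6-fold higher number from compound 2 to compound 3 (0.20 log units; within the scatter), small in either direction. Compound 3 is therefore estimated at 30 nM, with a range from 8 nM to 120 nM.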

Compound 3, half-maximal inhibitory concentration: 72 nM
For compound 3 the middle estimate is 2.4-fold (0.38 log units) below the measured one; the measured number falls inside the stated range.
By their numbers in this assay, from the lowest: compound 2; then compound 3; then compound 1.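

Exchanging methyl for trifluoromethyl on an aromatic carbon ortho to a large group is not a neutral change in this assay: the 2-methylphenyl to 2-(trifluoromethyl)phenyl exchange gives a 3.8-fold higher number from compound 2 to compound 3 (0.58 log units; beyond the scatter) and so gives up part of the advantage held by compound 2. That advantage does not belong to methyl alone, since 2-(trifluoromethyl)phenyl in place of 4-chlorophenyl on the aromatic nitrogen still gives a 3.9-fold lower number from compound 1 to compound 3 (0.59 log units; beyond the scatter), so among these three compounds both groups at this place give lower numbers than the 4-chlorophenyl of compound 1, with methyl giving the lowest. Nothing available here accounts for the difference between methyl and trifluoromethyl at this place.

Going by these compounds, with only these two groups compared at this place, it stays open whether a chlorine atom, a methoxy group or an ethyl chain there would give a number nearer that of compound 2 or that of compound 3. On these data alone, it is equally open how a group carrying an amine or a carboxylic acid would fare at this place, and whether methyl would keep its lead over trifluoromethyl anywhere else on the shared core.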